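The source may hold more compounds than are shown below. What is called first, only, known or untested is meant among the compounds shown, and "the series" means these compounds.

Measured in a functional assay on DU-145 cells (Homo sapiens) for cytotoxicity, read by MTT assay; on this read-out higher numbers stand for weaker inhibition and lower numbers for stronger inhibition:
- Compound 1 `CC(C)=CC[C@@H](OC[C@@H](C)O)C1=CC(=O)c2c(O)ccc(O)c2C1=O`: 14300 nM
- Compound 2 `CCCCCCC(C)(O)CC(=O)O[C@H](CC=C(C)C)C1=CC(=O)c2c(O)ccc(O)c2C1=O`: > 100000 nM, a limit of the assay
- Compound 3 `CC(C)=CC[C@@H](OC(=O)C1CCOC1)C1=CC(=O)c2c(O)ccc(O)c2C1=O`: 47500 nM

Compound 3 holds the higher of the two true numbers, and the step to it reads a 3.3-fold higher number from compound 1 to compound 3 (0.52 log units; beyond the scatter). Compound 4 `CCCC(C)(O)CC(=O)O[C@H](CC=C(C)C)C1=CC(=O)c2c(O)ccc(O)c2C1=O` carries 2-hydroxy-2-methylpentyl in place of oxolan-3-yl on a carbonyl carbon. For the measured compounds named here, the closest measured change is the one that swaps 2-hydroxy-2-methyloctyl for oxolan-3-yl, an at least 2.1-fold lower number from compound 2 to compound 3 (0.32 log units; beyond the scatter). That step rests on (the limit of > 100000 nM in this assay, at which 1 of the 3 values shown sits). Its direction suggests that compound 4 will give a higher number, though the chain differs, so the expected change is small: a 1.5-fold higher number from compound 3 to compound 4 (0.17 log units; within the scatter). Compound 4 is estimated at 70000 nM, with an expected range of 25000 nM to 100000 nM.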

Compound 4, half-maximal inhibitory concentration: 75000 nM
Beside the measured number, compound 4's estimate is 1.1-fold (0.03 log units) below it; low and high end bracket the measured number.
By their numbers in this assay, from the lowest: compound 1; then compounds 3 and 4 (each within the scatter of the next). At a limit, above all of these: compound 2.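

In this assay, 2-hydroxy-2-methylpentyl takes the place of oxolan-3-yl on the carbonyl carbon, and the step reads a 1.6-fold higher number from compound 3 to compound 4 (0.20 log units; within the scatter). Exchanging 2-hydroxypropyl on the oxygen for (2-hydroxy-2-methylpentyl)carbonyl gives a larger step, a 5.2-fold higher number from compound 1 to compound 4 (0.72 log units; beyond the scatter). Hydrogen in place of propyl on a saturated chain carbon, four bonds along the chain from an oxygen on a saturated carbon, gives an at least 1.3-fold lower number from compound 2 to compound 4 (0.12 log units; that floor lies within the scatter). Compound 2 stands at a limit, so this step is only a floor: the limit of > 100000 nM in this assay, at which 1 of the 4 values shown sits.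

From the compounds shown here alone, it remains open whether an amine or a carboxylic acid on this chain would move the number beyond the scatter. Also open, going by these compounds, is how a chain without the hydroxyl group would read.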